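This account rests on a few compounds, and the source may have more. Where it says the series, first, only, none or still open, it means among the compounds named here.

Compound 1 `Cc1ccn(-c2ccc(Cn3cc(C(=O)O)c(=O)c4ccncc43)cc2)n1`: 98.9%
Compound 2 `O=C(O)c1cn(Cc2ccc(-c3ccccc3)cc2)c2ncccc2c1=O`: 99.7%

Both compounds were measured in an ADME assay on the whole organism (serum) for protein binding, with Rattus norvegicus as the target, using equilibrium dialysis. Compound 2 has the lower unbound fraction of the two, and the gap to compound 1 lies beyond the scatter. Compound 3 `O=C(O)c1cn(Cc2ccc(-n3cccn3)cc2)c2ncccc2c1=O` keeps the core of compound 2, with 1H-pyrazol-1-yl in place of phenyl on an aromatic carbon. Among the compounds with values here, no measured pair isolates this change. Compound 1 also carries a pyrazolyl group, on another core, and gives 98.9%, so a moderate shift towards more free compound is expected. The expected change is a 3.0-fold higher unbound fraction from compound 2 to compound 3 (0.48 log units; beyond the scatter). For compound 3 the estimated value is 99.1%, with an expected range of 98.2% to 99.7%.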

Compound 3, plasma protein binding: 95.2%
Beside the measured number, compound 3's estimate is 5.3-fold (0.73 log units) (unbound fraction) below it; the measured number lies below the stated range.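

In this assay, 1H-pyrazol-1-yl in place of phenyl, para to a large group, gives a 16-fold higher unbound fraction from compound 2 to compound 3 (1.20 log units; beyond the scatter) on the shared core. Within the data shown here, this is the first step that isolates a single place, and it shows that plasma protein binding is sensitive to the group at this position. Nothing available accounts for the size of this step.

From the compounds shown here alone, whether morpholine or methoxy at this position would also leave more compound free remains open. So does whether the step carries over to the core of compound 1.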